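Cytotoxicity series: from hydroxyethyl to methoxycyclohexyl

A few compounds are considered here, and "the series" means these few. Any claim that something is new, unique, unknown or untested is made for them only; others in the source may bear on it.

Measured in a functional assay on LNCaP cells (Homo sapiens) for cytotoxicity; a higher number here means a weaker inhibitor, a lower number a stronger inhibitor:
- compound 1 `CNC(=O)Nc1ccc(-c2nc(N3CC4CCC(C3)O4)c3cnn(CCO)c3n2)cc1`: 650 nM
- compound 2 `O=C(Nc1ccncc1)Nc1ccc(-c2nc(N3CC4CCC(C3)O4)c3cnn(C4CCC5(CC4)OCCO5)c3n2)cc1`: 1 nM
- compound 3 `CCNC(=O)Nc1ccc(-c2nc(N3CC4CCC(C3)O4)c3cnn(C4CCC5(CC4)OCCO5)c3n2)cc1`: 1 nM

Compound 1 holds the highest number of the three, well beyond the scatter from the other two. The next structure is compound 4 `CNC(=O)Nc1ccc(-c2nc(N3CC4CCC(C3)O4)c3cnn([C@H]4CC[C@H](OC)CC4)c3n2)cc1`, which keeps the rest of compound 1 and changes one group: 4-methoxycyclohexyl in place of 2-hydroxyethyl on an aromatic nitrogen.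

Within the data shown here, the only measured step is no change at the digits printed from compound 2 to compound 3 (within the scatter). It lies at the amide-type nitrogen, not at the aromatic nitrogen that changes here, and it stays within the scatter. Compound 3, at 1 nM, carries a ring-containing group on that aromatic nitrogen, whereas compound 1, at 650 nM, carries 2-hydroxyethyl. These two also differ at the amide-type nitrogen, and 4-methoxycyclohexyl itself has no measured value, so the comparison is indirect. A large move to a lower number is nevertheless expected in this assay. The expected step is a 160-fold lower number from compound 1 to compound 4 (2.21 log units; beyond the scatter). The estimate for compound 4 is 4 nM, with an expected range of 1 nM to 30 nM.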

Compound 4, half-maximal inhibitory concentration: 2 nM
Compound 4: the middle estimate sits 2.0-fold (0.30 log units) above what was measured, and the stated range covers the measured number.
By their numbers in this assay, from the lowest: compounds 2, 3 and 4 (each within the scatter of the next); then compound 1.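

In this assay, 4-methoxycyclohexyl in place of 2-hydroxyethyl on an aromatic nitrogen gives a 330-fold lower number from compound 1 to compound 4 (2.51 log units; beyond the scatter), so this position alone, with the rest of the structure held, can carry a large step. Among these compounds, the earlier compounds could not show this, as the only earlier step lay at the amide-type nitrogen. The change adds a six-membered non-aromatic ring of carbon only and removes the hydrogen-bond donor of 2-hydroxyethyl, and no available evidence bears on what lies behind the step.

Still open, from the compounds shown here alone, is whether the ring or the loss of the hydroxyl accounts for the step: cyclohexyl, 2-methoxyethyl and 4-hydroxycyclohexyl on this nitrogen would separate the two. Also open, going by these compounds, are the role of the two defined stereocentres and how an amine on the cyclohexyl ring would read in this assay.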